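The source may hold more compounds than are shown below. What is called first, only, known or untested is meant among the compounds shown, and "the series" means these compounds.

Among the measured compounds shown here, in a functional assay on HEK293 cells for agonist activity at G-protein coupled receptor 39 (Homo sapiens), read by scintillation proximity assay and inositol phosphate accumulation, with a stated time of 75 min, in the presence of a further agent that is not named here (a higher number here means that more compound is needed for the effect, a lower number that less compound is needed), compound 1 `Cc1nn(-c2ncnc3nc[nH]c23)c2c1C(OCCc1ccccc1)CC(=O)N2` gives 3 nM, the lowest of the two numbers measured so far. Compound 2 `Cc1cc(C)n(CCOC2CC(=O)Nc3c2c(C)nn3-c2ncnc3nc[nH]c23)n1` gives 16 nM. For the measured compounds named here, the only measured step is a 5.3-fold higher number from compound 1 to compound 2 (0.73 log units; beyond the scatter), in which 3,5-dimethyl-1H-pyrazol-1-yl replaces phenyl on a saturated chain carbon, two bonds along the chain from an oxygen on a saturated carbon.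

Compound 3 `Cc1nn(-c2ncnc3nc[nH]c23)c2c1C(OCc1ccccc1C#N)CC(=O)N2` has not yet been measured. It differs from compound 1 as follows: 2-cyanophenyl in place of benzyl on a saturated chain carbon bound to an oxygen on a saturated carbon. Seen one bond further out, the same difference reads phenethyl to 2-cyanobenzyl.

That measured step bears on compound 3 only loosely: it alters the ring at the end of the same ether chain, but in a different way, and it was modest in size and raised the number. Going by the values given here, no measured pair tests a shorter chain or a nitrile. A modest rise in number is therefore expected, a 2.7-fold higher number from compound 1 to compound 3 (0.43 log units; beyond the scatter). Compound 3 is estimated at 8 nM, with a likely range from 2 nM to 30 nM.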

Compound 3, half-maximal effective concentration: 8 nM
Compound 3: the middle estimate sits on the measured number at the digits printed; the measured number falls inside the stated range.
By their numbers in this assay, from the lowest: compound 1; then compounds 3 and 2 (each within the scatter of the next).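

In this assay, replacing phenethyl with 2-cyanobenzyl on the ether oxygen gives a 2.7-fold higher number from compound 1 to compound 3 (0.43 log units; beyond the scatter), so this position tolerates a change in both the chain and its ring while the number stays in the low nanomolar range. The new comparison with the pyrazole compound gives a 2.0-fold lower number from compound 2 to compound 3 (0.30 log units; within the scatter), which lies within the scatter, so these two quite different end groups cannot be told apart here, and both sit beyond the scatter from the phenethyl ether of compound 1. No measurement available here explains these differences, whether for the chain, the nitrile or the pyrazole.

The step from compound 1 to compound 3 alters the chain and adds the nitrile at once, so the compounds shown do not reveal how much of the rise belongs to each change. As far as these compounds go, a plain benzyl group without the nitrile and a 2-cyanophenethyl group would separate the two, while an amine or a carboxylic acid at the end of the chain, or a longer chain such as 3-phenylpropyl, remains open.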